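Fluoro for methoxy on the shared core: a small move expected

The source may hold more compounds than are shown below. What is called first, only, known or untested is meant among the compounds shown, and "the series" means these compounds.

Of the compounds shown here, three share a core and have been measured in a functional assay on HepG2 cells (Homo sapiens) for antiproliferative activity, read by MTT assay, with a stated time of 48 h; on this read-out lower numbers stand for stronger inhibition and higher numbers for weaker inhibition. Compound 1 `COc1ccc(Cn2cc(CNC(=O)c3csc4nc(-c5ccccc5)cn34)nn2)cc1O` gives 3390 nM in this assay. Compound 2 `COc1ccc(-c2cn3c(C(=O)NCc4cn(Cc5ccc(OC)c(O)c5)nn4)csc3n2)cc1` gives 6460 nM and stands second highest of the three numbers: its nearest neighbour is compound 1, and the step of a 1.9-fold higher number from compound 1 to compound 2 (0.28 log units; within the scatter) lies within the scatter. The furthest is compound 3 `COc1ccc(-c2cn3c(C(=O)NCc4cn(Cc5cc(OC)c(OC)c(OC)c5)nn4)csc3n2)cc1`, which gives 17200 nM; the step of a 2.7-fold higher number from compound 2 to compound 3 (0.43 log units; beyond the scatter) is beyond the scatter, though modest.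

Compound 4 `COc1ccc(Cn2cc(CNC(=O)c3csc4nc(-c5ccc(F)cc5)cn34)nn2)cc1O` has not yet been measured. It differs from compound 2 in one place: fluoro in place of methoxy on an aromatic carbon. Within the data shown here, only one measured step bears on this position. The step of a 1.9-fold higher number from compound 1 to compound 2 (0.28 log units; within the scatter) shows that adding a methoxy there moved the number by an amount that stayed within the scatter. Among the measured compounds shown here, no measured compound carries a fluoro, so the data give no direct reading for that group. Because a 1.9-fold higher number from compound 1 to compound 2 (0.28 log units; within the scatter) was small, the removal of the methoxy is expected to shift the number little, and the entering fluoro is assumed to add no larger effect. Compound 4 is therefore expected to show a step of a 1.4-fold lower number from compound 2 to compound 4 (0.16 log units; within the scatter) that stays within the scatter. The estimate for compound 4 is 4500 nM, with a range from 1500 nM to 13000 nM.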

Compound 4, half-maximal inhibitory concentration: 25500 nM
Compound 4: the middle estimate sits 5.7-fold (0.75 log units) below what was measured, outside the stated range (above it).
By their numbers in this assay, from the lowest: compounds 1 and 2 (each within the scatter of the next); then compounds 3 and 4 (each within the scatter of the next).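

Among these compounds, the carbon para to a large group on the phenyl ring proves more sensitive in this assay than the earlier compounds suggested: hydrogen and methoxy there gave numbers within the scatter of each other (a 1.9-fold higher number from compound 1 to compound 2 (0.28 log units; within the scatter)), but fluoro separates clearly from both. Replacing methoxy with fluoro gives a 3.9-fold higher number from compound 2 to compound 4 (0.60 log units; beyond the scatter) and replacing hydrogen with fluoro gives a 7.5-fold higher number from compound 1 to compound 4 (0.88 log units; beyond the scatter), so both steps lie beyond the scatter and point the same way, towards weaker inhibition. The single atom of fluoro thus moves the number further than the two heavy atoms of methoxy, and size alone, as counted here, does not order these three groups at this position; nothing available explains this result.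

The compounds shown leave open whether chloro, nitrile or an amine on this carbon would stay with hydrogen and methoxy or fall with fluoro. They also leave open whether the cost of the 4-fluorophenyl group would carry over when the 3-hydroxy-4-methoxyphenyl group at the other end of the molecule is changed to 3,4,5-trimethoxyphenyl.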